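The compounds below may be only part of what the source reports. "The series", "measured", "known", "first", "only" and "open" are said of these compounds alone.

Measured compounds:
compound 1, `COc1cc(/C=C/c2c[nH]c3ccccc23)cc(OC)c1OC`, 3230 nM
compound 2, `COc1cc(/C=C/c2cn(C)c3ccccc23)cc(OC)c1OC`, 3090 nM
compound 3, `COc1cc(/C=C/c2ccc3[nH]ccc3c2)cc(OC)c1OC`, 250 nM

In a functional assay on HeLa cells (Homo sapiens) for inhibition (on this read-out lower numbers stand for stronger inhibition and higher numbers for weaker inhibition), compound 1 gives 3230 nM and compound 2 gives 3090 nM. The step between them, a 1.0-fold lower number from compound 1 to compound 2 (0.02 log units; within the scatter), is the change (methyl in place of hydrogen on an aromatic nitrogen). Compound 3 carries the same atoms joined differently; the difference between its core and that of compound 1 is not broken down here. In this assay compound 3 gives 250 nM, which sets it apart from both compound 1 and compound 2 by more than the scatter.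

Compound 4, `COc1cc(/C=C/c2ccc3c(ccn3C)c2)cc(OC)c1OC`, has not yet been measured. It differs from compound 3 by methyl in place of hydrogen on an aromatic nitrogen. Within the data shown here, this is the same kind of change as the one from compound 1 to compound 2, though not the same: in compound 1 the place is also two ring bonds from the ring atom that bears a large group, while in compound 3 it is not.

Among the measured compounds shown here, since the only measured example of this change, a 1.0-fold lower number from compound 1 to compound 2 (0.02 log units; within the scatter), stayed within the scatter, compound 4 is expected to sit close to compound 3, and the step of a 1.1-fold higher number from compound 3 to compound 4 (0.03 log units; within the scatter) is estimated to be small. For compound 4 the expected value in this assay is 270 nM, with an estimated range from 120 nM to 650 nM.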

Compound 4, half-maximal inhibitory concentration: 24 nM
The estimate for compound 4 lay 11-fold (1.05 log units) above the measured number; the whole stated range lies above it.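

In this assay, methyl in place of hydrogen on an aromatic nitrogen gave a 10-fold lower number from compound 3 to compound 4 (1.02 log units; beyond the scatter), so a change that stayed within the scatter on the core of compound 1 made a large difference on the core of compound 3. The size of this step therefore did not carry from one core to the other, and the two steps differ by more than the scatter: the same change on two cores in this assay, a 1.0-fold lower number (0.02 log units; within the scatter) from compound 1 to compound 2 and a 10-fold lower number (1.02 log units; beyond the scatter) from compound 3 to compound 4, 10-fold (1.00 log units) apart, beyond the scatter of two such steps This shows that, in this series, a step measured on one core is a poor guide to the same change on the other, but it does not show why the two cores differ, and two pairs give no rule for how the change would behave on any further core.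

The compounds shown leave open whether a longer chain on the same aromatic nitrogen, such as ethyl or propyl, or an acetyl group there, would go along with methyl on the core of compound 3 or lose the gain. They also leave open whether the large step seen in this assay would appear in any other kind of assay, since this single cell read-out is the only one available.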